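The compounds below may be only part of what the source reports. "The series", "measured", "known", "first", "only" and "open" are said of these compounds alone.

In a functional assay on MOLT-4 cells (Homo sapiens) for cytotoxicity, with a stated time of 72 h (a lower number here means a stronger inhibitor, a higher number a weaker inhibitor), compound 1 `Cc1ccc(/C=C2\CCC/C(=C\c3cccc([N+](=O)[O-])c3)C2=O)cc1` gives 9530 nM, the lowest number among the three measured compounds. Compound 2 `O=C1CCCC/C1=C\c1ccccc1[N+](=O)[O-]` gives 33300 nM and compound 3 `COc1cc(/C=C2\CCC/C(=C\c3cccc([N+](=O)[O-])c3)C2=O)cc(OC)c1OC` gives 44000 nM, and both of these gaps to compound 1 lie beyond the usual scatter. Compound 4 `O=C1/C(=C/c2ccc(Cl)cc2)CCC/C1=C\c1cccc([N+](=O)[O-])c1` has not yet been measured. It differs from compound 1 in one place: chloro in place of methyl on an aromatic carbon. Going by the values given here, no measured pair shows this exchange, so nothing in the data says how large its effect is. The expectation is a step of a 1.1-fold lower number from compound 1 to compound 4 (0.02 log units; within the scatter) of no more than the scatter, in either direction. For compound 4 the estimated value is 9000 nM, with a range from 3000 nM to 27000 nM.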

Compound 4, half-maximal inhibitory concentration: 2020 nM
For compound 4 the middle estimate is 4.5-fold (0.65 log units) above the measured one, outside the stated range (below it).
By their numbers in this assay, from the lowest: compound 4; then compound 1; then compounds 2 and 3 (each within the scatter of the next).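

Exchanging 4-methylphenyl for 4-chlorophenyl gives a 4.7-fold lower number from compound 1 to compound 4 (0.67 log units; beyond the scatter) in this assay. Going by these compounds alone, this is the first measured sign that the group at this place on the aromatic ring, para to a large group, can shift the number by more than the scatter, although only one heavy atom changes. No measurement here explains the shift.

On these data alone, whether fluoro, bromo or an amine at this place would lower the number further remains open. So does whether the same exchange gives a similar step on a different core.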